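Azido-to-azidoethoxy chain extension on two urea cores

The compounds below may be only part of what the source reports. "The series", "measured", "known", "first", "only" and "open" are said of these compounds alone.

Measured so far:
- Compound 1 `CCOC(=O)c1cn(Cc2c(F)cccc2F)c2nc(-c3ccc(NC(=O)NCc4cn(CCOCCN=[N+]=[N-])nn4)cc3)c(CN(C)Cc3ccccc3)n2c1=O`: in a functional assay on CHO cells for antagonist activity at Gonadotropin-releasing hormone receptor (Homo sapiens), read by a luciferase reporter, with a stated time of 30 min (on this read-out higher numbers stand for weaker inhibition and lower numbers for stronger inhibition), compound 1 gives 3630 nM.
- Compound 3 `CCOC(=O)c1cn(Cc2c(F)cccc2F)c2nc(-c3ccc(NC(=O)NCc4cn(CCOCCOCCN=[N+]=[N-])nn4)cc3)c(CN(C)Cc3ccccc3)n2c1=O`: in this assay compound 3 gives 2400 nM.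
- Compound 2 `CCNC(=O)Nc1ccc(-c2nc3n(Cc4c(F)cccc4F)cc(C(=O)NCc4cn(CCOCCOCCN=[N+]=[N-])nn4)c(=O)n3c2CN(C)Cc2ccccc2)cc1`: in this assay compound 2 reaches only the limit < 10000 nM, which is a limit of the assay and not a number.

Compound 1 and compound 2 carry different cores; the difference between the two cores is not broken down here. Compound 3 arises from compound 1 by the change (2-azidoethoxy in place of azido on a saturated chain carbon, two bonds along the chain from an oxygen on a saturated carbon). This step, a 1.5-fold lower number from compound 1 to compound 3 (0.18 log units; within the scatter), leaves the read-out essentially unchanged.

Compound 4 `CCNC(=O)Nc1ccc(-c2nc3n(Cc4c(F)cccc4F)cc(C(=O)NCc4cn(CCOCCOCCOCCN=[N+]=[N-])nn4)c(=O)n3c2CN(C)Cc2ccccc2)cc1` is not yet measured. It arises from compound 2 by 2-azidoethoxy in place of azido on a saturated chain carbon, two bonds along the chain from an oxygen on a saturated carbon, the same change as between compound 1 and compound 3, at the same place in the chain.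

For compound 4 the expected step is a step that the limit leaves unreadable from compound 2 to compound 4, small, resting on a 1.5-fold lower number from compound 1 to compound 3 (0.18 log units; within the scatter) and on compound 2 standing at the limit (the limit of < 10000 nM in this assay, at which 1 of the 3 values shown sits). Compound 4 is thus estimated at 5000 nM, expected to lie between 1500 nM and 10000 nM, with a real chance that only a limit is reported again.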

Compound 4, half-maximal inhibitory concentration: < 10000 nM
Compound 4 gave a limit, no number (the forecaster's own chance of this, stated with the estimate: 55%); the middle value does not contradict the limit.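

Compound 2 and compound 4 both give a limit and not a number, so no step can be read between them: the limit of < 10000 nM in this assay, at which 2 of the 4 values shown sit.

The compounds shown leave open whether 2-azidoethoxy in place of azido does anything to the read-out on the core of compound 2, and whether it behaves there as it does on the core of compound 1.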